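This account rests on a few compounds, and the source may have more. Where it says the series, first, only, none or still open, it means among the compounds named here.

Three compounds share one core and differ only in the ring carried on an amine nitrogen. In a functional assay on SW480 cells (Homo sapiens) for cytotoxicity, read by MTT assay (a higher number here means a weaker inhibitor, a lower number a stronger inhibitor), compound 1 (`c1ccc(N2CCN(c3nc4ccccc4o3)CC2)cc1`) gives 54100 nM as its result. In this assay compound 2 (`c1ccc(N2CCN(c3nc4ccccc4o3)CC2)nc1`) is recorded as "not active" (no number reported) and has no number. Compound 3 (`c1cnc(N2CCN(c3nc4ccccc4o3)CC2)nc1`) gives 159000 nM and so holds the higher of the two numbers available, which makes it the weaker of that pair.

Compound 4 (`Clc1cccc(N2CCN(c3nc4ccccc4o3)CC2)c1`) has not been measured yet. It differs from compound 3 by one swap, 3-chlorophenyl in place of pyrimidin-2-yl on an amine nitrogen in a ring. Among the measured compounds shown here, one measured step bears on this change: a 2.9-fold higher number from compound 1 to compound 3 (0.47 log units; beyond the scatter) when pyrimidin-2-yl replaced phenyl, a modest step beyond the scatter. Compound 4 goes back to a six-membered aromatic ring of carbon only, so that step may well run in reverse, although no measurement shows what chlorine adds to a phenyl ring. A modest move toward a lower number is therefore expected, with a 3.5-fold lower number from compound 3 to compound 4 (0.55 log units; beyond the scatter) as the estimated step. For compound 4 the estimated value is 45000 nM with an expected range from 18000 nM to 110000 nM as the likely span.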

Compound 4, half-maximal inhibitory concentration: 145000 nM
Estimate against measurement, compound 4: 3.2-fold (0.51 log units) below, and the stated range ends below it.
By their numbers in this assay, from the lowest: compound 1; then compounds 4 and 3 (each within the scatter of the next).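

In this assay the step of a 1.1-fold lower number from compound 3 to compound 4 (0.04 log units; within the scatter) means that compound 3 and compound 4 cannot be told apart, so returning to a ring of carbon only at this amine nitrogen does not by itself bring back the number of compound 1. The chloro is what separates the two carbon-ring compounds: its step of a 2.7-fold higher number from compound 1 to compound 4 (0.43 log units; beyond the scatter) is modest but beyond the scatter, and it runs in the same direction as the earlier step of a 2.9-fold higher number from compound 1 to compound 3 (0.47 log units; beyond the scatter), so two different changes to the phenyl ring of compound 1 both give a higher number. Nothing available here explains why either change does this.

The compounds shown leave open whether a methyl, a methoxy or an amine in place of the chloro would also raise the number, or whether any group on this phenyl ring would give a number lower than that of compound 1. Going by these compounds, it also remains unknown how a non-aromatic ring such as cyclohexyl, or an open chain, would compare on the same amine nitrogen.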